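Isobutyl for 3-methylphenyl on the core of compound 1

The source may hold more compounds than are shown below. What is called first, only, known or untested is meant among the compounds shown, and "the series" means these compounds.

Measured compounds:
compound 1, `Cc1cccc(Cn2c(OC3CCN(C(=O)c4ccco4)CC3)nc3ccccc32)c1`, 68.3%
compound 2, `O=C(C1CC1)N1CCN(Cc2nc3ccccc3n2Cc2ccccc2F)CC1`, 40.7%

The two compounds were run in an assay on isolated protein for inhibition of aldehyde dehydrogenase 1A1 (Homo sapiens), read by spectrophotometry, tested at 10 uM; a higher number here means more inhibition at the concentration tested (going by the name of the read-out), a lower number less inhibition. Compound 1 gives 68.3%, the higher of the two numbers. Compound 2 gives 40.7%, and the gap between compound 2 and compound 1 is beyond the scatter of this assay; the two share no single-point difference, so nothing more is drawn from that pair.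

The account now turns to compound 3, `CC(C)CCn1c(OC2CCN(C(=O)c3ccco3)CC2)nc2ccccc21`, which has not yet been measured in this assay. It differs from compound 1 in one place: isobutyl in place of 3-methylphenyl on a saturated chain carbon bound to an aromatic nitrogen. What leaves carries one six-membered aromatic ring of carbon only; what enters is a chain with no ring. Going by the values given here, no measured pair in the set shows this kind of change, so the size of the step has to be estimated rather than read off.

A step downward from compound 1 is expected, of moderate size, and the estimated step of a number 18.3 percentage points lower from compound 1 to compound 3 (beyond the scatter) reflects this. Compound 3 is therefore expected to give about 50% in this assay, with a range from 25% to 75%.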

Compound 3, a percentage reported as inhibition, at one concentration (the size of the read-out at that concentration, not a potency): 30.8%
Compound 3: middle estimate off by 19.2 percentage points, on the high side, within the range that was stated.
By their numbers in this assay, from the lowest: compounds 3 and 2 (each within the scatter of the next); then compound 1.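

Going by these compounds alone, at this place, on a saturated chain carbon bound to an aromatic nitrogen, the swap gives the first single-point comparison in this assay, and the group there clearly counts: isobutyl in place of 3-methylphenyl gives a number 37.5 percentage points lower from compound 1 to compound 3 (beyond the scatter). With everything else in compound 1 held unchanged, the lower number comes with the loss of the six-membered aromatic ring of carbon only and a fall from 7 heavy atoms to 4 in the exchanged group, so the rest of the molecule alone does not hold inhibition at the level of compound 1. Nothing measured here bears on why the number falls, and the step stands as an observation only.

Within the data shown here, the single step changes the ring, the methyl and the size of the group together, and it leaves open which of these goes with the difference. From the compounds shown here alone, a cyclohexyl group, an unsubstituted phenyl or a pyridine ring at the same place would separate these features, while the effect of a longer chain or an amine there also remains open.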